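Removing One Chloro From the Dichlorophenyl Ring

This account rests on a few compounds, and the source may have more. Where it says the series, first, only, none or still open, it means among the compounds named here.

Compound 1, `Cc1cccc(-c2noc(C3CC(=O)N(c4ccc(C)c(Cl)c4)C3)n2)c1`, gives 240 nM in an in vitro functional assay on HEK293-A cells for positive allosteric modulation of metabotropic glutamate receptor 5 (Homo sapiens), read by FLIPR and calcium flux; a higher number here means that more compound is needed for the effect, a lower number that less compound is needed.
Compound 2, `Cc1cccc(-c2noc(C3CC(=O)N(c4ccc(Cl)c(Cl)c4)C3)n2)c1`, gives 390 nM in this assay.
Compound 3, `O=C1CC(c2nc(-c3cccc(F)c3)no2)CN1c1ccc(Cl)c(Cl)c1`, gives 3200 nM in this assay.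

Compound 2 stands second highest of these three numbers: the step of a 1.6-fold higher number from compound 1 to compound 2 (0.21 log units; within the scatter) lies within the scatter, whereas the step of an 8.2-fold higher number from compound 2 to compound 3 (0.91 log units; beyond the scatter) goes beyond it.

Compound 4, `Cc1cccc(-c2noc(C3CC(=O)N(c4ccc(Cl)cc4)C3)n2)c1`, differs from compound 2 by hydrogen in place of chloro on an aromatic carbon. Within the data shown here, only one measured step concerns the same ring, namely a 1.6-fold higher number from compound 1 to compound 2 (0.21 log units; within the scatter), and it stayed within the scatter. A small move is therefore expected for compound 4, estimated as a 1.3-fold higher number from compound 2 to compound 4 (0.11 log units; within the scatter), not beyond the scatter in either direction. Compound 4 is expected to give 500 nM, with a likely range from 200 nM to 1300 nM.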

Compound 4, half-maximal effective concentration: 170 nM
Estimate against measurement, compound 4: 2.9-fold (0.47 log units) above; measured number outside the range, below it.
By their numbers in this assay, from the lowest: compounds 4, 1 and 2 (each within the scatter of the next, the first and the last beyond it); then compound 3.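

In this assay, replacing the chloro on the 3,4-dichlorophenyl ring with hydrogen, which leaves 4-chlorophenyl, gives a 2.3-fold lower number from compound 2 to compound 4 (0.36 log units; beyond the scatter). This position therefore does not need a chloro, and here its removal lowers the number rather than leaving it unchanged or raising it. The 4-chlorophenyl and 3-chloro-4-methylphenyl rings cannot be told apart, with a 1.4-fold lower number from compound 1 to compound 4 (0.15 log units; within the scatter).

On these data alone, whether a methoxy group or an amine at this position would do as well remains open. Why hydrogen outperforms chloro here also remains open, as no supporting data bear on it.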